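From benzamido to 3-acetylphenyl on a double-bonded nitrogen

The source may hold more compounds than are shown below. What is called first, only, known or untested is meant among the compounds shown, and "the series" means these compounds.

Compound 1 `O=C1Nc2ccc(S(=O)(=O)N3CCOCC3)cc2/C1=N/c1ccc(O)cc1` value 259000 nM measured
Compound 2 `O=C1Nc2ccc(S(=O)(=O)N3CCOCC3)cc2/C1=N/NC(=O)c1ccccc1` value 295000 nM measured

Among the compounds with values here, both values come from an ADME assay on WI-38 cells (Homo sapiens) for cytotoxicity, read by sulforhodamine B assay, with a stated time of 24 h (a higher number here means a weaker inhibitor, a lower number a stronger inhibitor), and they are the only numbers available. Within the data shown here, the single measured step is a 1.1-fold higher number from compound 1 to compound 2 (0.06 log units; within the scatter) and it leaves compound 2 level with compound 1, with no order between them.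

Compound 3 `CC(=O)c1cccc(/N=C2\C(=O)Nc3ccc(S(=O)(=O)N4CCOCC4)cc32)c1` has not yet been measured. It carries 3-acetylphenyl in place of benzamido on a double-bonded nitrogen, and the shared core is unchanged. Among the measured compounds shown here, the counted difference from compound 2 is 3-acetylphenyl in place of benzamido on a double-bonded nitrogen and it touches only that group.

For the measured compounds named here, the one step that bears on this change sits at the same place, where 4-hydroxyphenyl and benzamido differ by a 1.1-fold higher number from compound 1 to compound 2 (0.06 log units; within the scatter) and nothing more. That is thin evidence, since it rests on two compounds and neither carries 3-acetylphenyl. Even so, no step beyond the scatter is expected in this assay here. From the compounds shown here alone, the expected step is a 1.1-fold lower number from compound 2 to compound 3 (0.04 log units; within the scatter) and either direction remains open. The estimated value for compound 3 is 270000 nM with an expected range from 130000 nM to 500000 nM for the measurement.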

Compound 3, half-maximal inhibitory concentration: 177000 nM
For compound 3 the middle estimate is 1.5-fold (0.18 log units) above the measured one, and the stated range covers the measured number.
By their numbers in this assay, from the lowest: compounds 3, 1 and 2 (each within the scatter of the next).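

In this assay, a third group on the double-bonded nitrogen gives a 1.7-fold lower number from compound 2 to compound 3 (0.22 log units; within the scatter) and a 1.5-fold lower number from compound 1 to compound 3 (0.17 log units; within the scatter), so compound 3 stands level with both earlier compounds. The change from benzamido to 3-acetylphenyl keeps the count of heavy atoms and the carbon-only aromatic ring but leaves no hydrogen-bond donor in the group, and this difference does not separate compound 3 from compound 2 beyond the scatter. Thus a group joined through its aromatic ring and carrying an acetyl group now reads alike with the two earlier groups at this position, though nothing at hand accounts for that likeness.

From the compounds shown here alone, what remains open is whether this position stays as level with a group of another kind, such as an amine or a carboxylic acid on the aromatic ring, or a longer chain in its place. All three compounds share one core and one cell assay, so they also leave open whether the same level reading would hold on a different core or in this assay at values outside this narrow band.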